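A few compounds are considered here, and "the series" means these few. Any claim that something is new, unique, unknown or untested is made for them only; others in the source may bear on it.

Measured in a toxicity assay on KB cells (Homo sapiens) for cytotoxicity, read by fluorescence, with a stated time of 3 days; a lower number here means that less compound is needed, a higher number that more compound is needed for the effect:
- Compound 1 `CCCCOC(=O)CNC(=O)[C@H](CSc1ccc([N+](=O)[O-])cc1[N+](=O)[O-])NC(=O)CC[C@H](NC(=O)OC)C(=O)OCCCC`: > 300 uM (a limit of the assay, not a number)
- Compound 2 `CCCCOC(=O)CNC(=O)[C@H](CSc1ccc([N+](=O)[O-])cc1[N+](=O)[O-])NC(=O)CC[C@H](NC(=O)CCC(C)C)C(=O)OCCCC`: 84 uM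
- Compound 3 `CCCCOC(=O)CNC(=O)[C@H](CSc1ccc([N+](=O)[O-])cc1[N+](=O)[O-])NC(=O)CC[C@H](NC(=O)CCc1c[nH]c2ccccc12)C(=O)OCCCC`: 26 uM

Compound 2 holds the higher of the two exact numbers, with a 3.2-fold lower number from compound 2 to compound 3 (0.51 log units; beyond the scatter). Compound 4 `CCCCOC(=O)CNC(=O)[C@H](CSc1ccc([N+](=O)[O-])cc1[N+](=O)[O-])NC(=O)CC[C@H](NC(C)=O)C(=O)OCCCC` has hydrogen in place of isobutyl on a saturated chain carbon bound to a carbonyl carbon, so isopentylcarbonyl becomes acetyl.

Replacing methoxy on that carbonyl gave an at least 3.5-fold lower number from compound 1 to compound 2 (0.55 log units; beyond the scatter) with isopentyl and an at least 11-fold lower number from compound 1 to compound 3 (1.06 log units; beyond the scatter) with 2-(1H-indol-3-yl)ethyl. Going by the values given here, no compound here goes against this trend, but none carries methyl. Partly reversing the trend, the expected change is a 2.4-fold higher number from compound 2 to compound 4 (0.38 log units; beyond the scatter), and this assay may return only a limit. Compound 4 is estimated at 200 uM, within an expected range of 90 uM to 420 uM.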

Compound 4, concentration for half-maximal effect: > 300 uM
Compound 4: no number, only a limit; the forecaster's own chance of this, stated with the estimate: 40%; at least 1.5-fold (0.17 log units) between middle value and limit.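

In this assay, removing isobutyl from the saturated chain carbon bound to the carbonyl carbon gives an at least 3.5-fold higher number from compound 2 to compound 4 (0.55 log units; beyond the scatter), and removing (1H-indol-3-yl)methyl from it gives an at least 11-fold higher number from compound 3 to compound 4 (1.06 log units; beyond the scatter). Among these compounds, only the two with the longer groups, isopentyl and 2-(1H-indol-3-yl)ethyl, reach an exact number, and none goes against this. Acetyl, like the methoxy-bearing carbonyl group, stays at a limit of the assay: the limit of > 300 uM in this assay, at which 2 of the 4 values shown sit.

The step from compound 1 to compound 4 cannot be read, since both values are limits. Also open, as far as these compounds go, is whether a propyl chain would already reach an exact number, and what an amine or a carboxylic acid on that chain would give.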